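Isopropylcarbamoyl in Place of Cyclohexylcarbonyl on the Shared Core

The source may hold more compounds than are shown below. What is called first, only, known or untested is meant among the compounds shown, and "the series" means these compounds.

Measured compounds:
- compound 1, `COC(=O)/C=C/c1cccc(N(Cc2ccc(/C=C/c3cccc(C(F)(F)F)c3)cc2)C(=O)NC(C)C)c1`, gives 932 nM in an assay on isolated protein with Bile acid receptor (Homo sapiens) as the target; a higher number here means that more compound is needed for the effect, a lower number that less compound is needed
- compound 2, `COC(=O)/C=C/c1cccc(N(Cc2ccc(/C=C/c3c(C)cc(C)cc3C)cc2)C(=O)NC(C)C)c1`, gives 431 nM in this assay
- compound 3, `COC(=O)/C=C/c1cccc(N(Cc2ccc(-c3cccc(C)c3)cc2)C(=O)C2CCCCC2)c1`, gives 109 nM in this assay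

Compound 3 stands lowest of the three, with compound 2 nearest and compound 1 furthest. Compound 4, `COC(=O)/C=C/c1cccc(N(Cc2ccc(-c3cccc(C)c3)cc2)C(=O)NC(C)C)c1`, differs from compound 3 by isopropylamino in place of cyclohexyl on a carbonyl carbon. Among the measured compounds shown here, the only measured step, a 2.2-fold lower number from compound 1 to compound 2 (0.33 log units; beyond the scatter), concerns the far ring and not the carbonyl substituent, so no step bears directly on this change. Compounds 1 and 2 both carry the isopropylcarbamoyl and give higher numbers than compound 3, but they also differ elsewhere. A modest rise is therefore expected, a 2.3-fold higher number from compound 3 to compound 4 (0.36 log units; beyond the scatter). Compound 4 is estimated at 250 nM, within 100 nM to 700 nM.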

Compound 4, half-maximal effective concentration: 1330 nM
Compound 4: middle estimate off by 5.3-fold (0.73 log units), on the low side, outside the stated range (above it).
By their numbers in this assay, from the lowest: compound 3; then compound 2; then compounds 1 and 4 (each within the scatter of the next).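

In this assay this carbonyl position proves highly sensitive: isopropylamino in place of cyclohexyl on a carbonyl carbon produces a large step (a 12-fold higher number from compound 3 to compound 4 (1.09 log units; beyond the scatter)). With the isopropylcarbamoyl kept, the steps at the far ring are smaller: 3-methylphenyl in place of 2-(2,4,6-trimethylphenyl)ethenyl gives a modest one (a 3.1-fold higher number from compound 2 to compound 4 (0.49 log units; beyond the scatter)), and 3-methylphenyl in place of 2-(3-(trifluoromethyl)phenyl)ethenyl stays within the scatter (a 1.4-fold higher number from compound 1 to compound 4 (0.15 log units; within the scatter)). Nothing available explains the large step at the carbonyl carbon. On these data alone, whether the ring or the nitrogen matters remains open: cyclohexylamino or isobutyl on that carbonyl carbon would separate the two.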